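The source may report more compounds than this note shows. Statements on the series, on what has been measured and on what is new or still open speak of the compounds shown alone.

Measured so far:
compound 1, `CCCCCCCCCCn1cc(Cn2c(CC)nc3nc(C(F)(F)F)ccc3c2=O)nn1`, giving 860 nM in a functional assay on A549 cells (Homo sapiens) for antiproliferative activity, read by sulforhodamine B assay, with a stated time of 48 h; a lower number here means a stronger inhibitor of growth, a higher number a weaker inhibitor of growth;
compound 2, `CCCCCCCCn1cc(Cn2c(CC)nc3nc(C(F)(F)F)ccc3c2=O)nn1`, giving 2870 nM;
compound 3, `CCCCCCCCCCn1cc(COc2nc(-c3ccccc3)nc3nc(C(F)(F)F)ccc23)nn1`, giving 2310 nM.

Compound 4, `CCCCCCCCn1cc(COc2nc(-c3ccccc3)nc3nc(C(F)(F)F)ccc23)nn1`, has not yet been tested. It differs from compound 3 by hydrogen in place of ethyl on a saturated chain carbon, eight bonds along the chain from an aromatic nitrogen. The same change, (hydrogen in place of ethyl on a saturated chain carbon, eight bonds along the chain from an aromatic nitrogen), separates compound 1 from compound 2, where it gave a 3.3-fold higher number from compound 1 to compound 2 (0.52 log units; beyond the scatter), a weakening. The cores of compound 1 and compound 3 differ in more than one way, and that difference is not broken down here. Among the compounds with values here, only one example of the change is on hand, so a step in the same direction, though not necessarily of the same size, is expected; the expected step is a 2.4-fold higher number from compound 3 to compound 4 (0.38 log units; beyond the scatter), resting on a 3.3-fold higher number from compound 1 to compound 2 (0.52 log units; beyond the scatter). Compound 4 is accordingly estimated at 5500 nM, most likely between 2000 nM and 15000 nM.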

Compound 4, concentration for 50% growth inhibition: 5330 nM
Beside the measured number, compound 4's estimate is 1.0-fold (0.01 log units) above it, and the stated range covers the measured number.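

In this assay, hydrogen in place of ethyl at this place on the chain gives a 2.3-fold higher number from compound 3 to compound 4 (0.36 log units; beyond the scatter), so the weakening seen on the core of compound 1 appears again on the core of compound 3. The two steps point the same way and do not differ in size beyond what repeat measurements would give: the same change on two cores in this assay, a 3.3-fold higher number (0.52 log units; beyond the scatter) from compound 1 to compound 2 and a 2.3-fold higher number (0.36 log units; beyond the scatter) from compound 3 to compound 4, 1.4-fold (0.16 log units) apart, within the scatter of two such steps. This shows that the change carried over between these two cores, but two cores cannot show that it would hold on any other core in the series. The compounds shown leave open whether a longer chain would lower the number further, and whether a chain carrying an amine would follow the same trend.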